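The compounds below may be only part of what the source reports. "The series", "measured", "known", "first", "only" and "open" are said of these compounds alone.

Measured so far in a functional assay on A549 cells (Homo sapiens) for antiproliferative activity, read by CCK-8 assay, with a stated time of 72 h; a lower number here means a stronger inhibitor of growth, a higher number a weaker inhibitor of growth:
Compound 1, `CCC1C(=O)N(C)c2cnc(-n3ccc4cc(C(N)=O)ccc43)nc2N1c1ccn(C)n1`, gives 39500 nM.
Compound 2, `CCC1C(=O)N(C)c2cnc(-n3ccc4cc(C(=O)NC(C)C)ccc43)nc2N1c1ccn(C)n1`, gives 22000 nM.
Compound 3, `CC[C@@H]1C(=O)N(C)c2cnc(-n3ccc4cc(C(=O)NCC(C)C)ccc43)nc2N1C1CCCC1`, gives 1730 nM.

Compound 3 stands at the lowest number of the three; compound 2 and compound 1 both lie above it, and each gap to compound 3 is beyond the scatter. Compound 2 and compound 3 differ in two places at once, so their gap cannot be tied to a single change.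

Compound 4, `CCCNC(=O)c1ccc2c(ccn2-c2ncc3c(n2)N(C2CCCC2)[C@H](CC)C(=O)N3C)c1`, differs from compound 3 by hydrogen in place of methyl on a saturated chain carbon bound to two saturated chain carbons. Among the measured compounds shown here, the only measured single-place step, a 1.8-fold lower number from compound 1 to compound 2 (0.25 log units; within the scatter), also concerns the amide part of the series and stayed within the scatter. A step that only trims one carbon from the amide chain is expected to stay within the scatter as well, with no direction beyond it; the expected step is a 1.2-fold higher number from compound 3 to compound 4 (0.06 log units; within the scatter). The estimate for compound 4 in this assay is 2000 nM, with an expected range from 700 nM to 6000 nM.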

Compound 4, concentration for 50% growth inhibition: 1640 nM
Estimate against measurement, compound 4: 1.2-fold (0.09 log units) above; low and high end bracket the measured number.
By their numbers in this assay, from the lowest: compounds 4 and 3 (each within the scatter of the next); then compounds 2 and 1 (each within the scatter of the next).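

Trimming the methyl on a saturated chain carbon bound to two saturated chain carbons, which turns isobutyl into propyl, gives a 1.1-fold lower number from compound 3 to compound 4 (0.02 log units; within the scatter) in this assay. Among the compounds shown here, this is the first single-place step read at this chain, and it shows that in this pair the methyl can be lost without a shift beyond the scatter, so the branched and the straight chain cannot be told apart here. No data on hand bear on why the number holds across this change.

Open, from the compounds shown here alone, is whether a longer chain such as pentyl, or a propyl chain ending in an amine or a carboxylic acid, would keep the number in this assay. Also open, going by these compounds, is whether the same trim stays as small when made on compound 2.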